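The compounds below may be only part of what the source reports. "The series", "measured", "known", "first", "only" and "open" are said of these compounds alone.

Three compounds were tested in a functional assay on HT-29 cells (Homo sapiens) for cytotoxicity, read by MTT assay, with a stated time of 72 h; on this read-out lower numbers stand for stronger inhibition of growth and higher numbers for weaker inhibition of growth. Compound 1 `CCOC(=O)Nc1ccc([Se]C#N)cc1` is the smallest of them; in this assay compound 1 gives 38000 nM. Compound 2 `C=CCOC(=O)Nc1ccc([Se][Se]c2ccc(NC(=O)OCC=C)cc2)cc1` is a larger, two-part compound, and compound 2 gives 52700 nM. Compound 3 `O=C(Nc1ccc([Se][Se]c2ccc(NC(=O)Oc3ccc(F)cc3)cc2)cc1)Oc1ccc(F)cc1` is built on the same two-part pattern with a different end group, and compound 3 gives 51900 nM. Compound 1 has the lowest number of the three, but its gaps to compound 2 and to compound 3 both lie within the usual scatter of repeated measurements, so on these numbers the three cannot be put in any order.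

Compound 4 `CCCCOC(=O)Nc1ccc([Se]C#N)cc1` has not yet been measured. It differs from compound 1 in one place: ethyl in place of hydrogen on a saturated chain carbon, two bonds along the chain from an oxygen next to a carbonyl group. Among the measured compounds shown here, no pair of measured compounds differs in only one place, so the data hold no direct step to compare with. Lengthening a chain in this way, with nothing else changed, is expected to give only a small step, most likely none beyond the scatter, in either direction. For compound 4 the expected step is a 1.3-fold lower number from compound 1 to compound 4 (0.10 log units; within the scatter). Compound 4 is therefore estimated at 30000 nM, with a range from 12000 nM to 80000 nM.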

Compound 4, concentration for total growth inhibition: 31300 nM
Compound 4: middle estimate off by 1.0-fold (0.02 log units), on the low side; the measured number falls inside the stated range.
By their numbers in this assay, from the lowest: compounds 4, 1, 3 and 2 (each within the scatter of the next).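

Among the compounds shown here, compound 4 gives the first direct reading of a single change in this set: in this assay the step is a 1.2-fold lower number from compound 1 to compound 4 (0.08 log units; within the scatter) and it comes from one change alone, ethoxy to butoxy, with the rest of compound 1 untouched. At this saturated chain carbon, two bonds along the chain from an oxygen next to a carbonyl group, ethyl in place of hydrogen therefore leaves the number indistinguishable from that of compound 1 within the scatter of repeated measurements. This place thus takes two more carbons with no detectable change on this read-out, something the three earlier compounds could not show, as no two of them differ in only one place.

As far as these compounds go, what stays open is whether a longer chain, a ring, or a different kind of group such as an amine or a carboxylic acid at this carbon would move the number beyond the scatter, and whether the same ethyl change would read alike on the two-part pattern of compound 2 and compound 3. Nothing in the data explains why the step is this small, and no separate measurement on either group bears on it.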